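Bromo in place of methoxy: compound 3 ahead

The source may report more compounds than this note shows. Statements on the series, on what has been measured and on what is new or still open speak of the compounds shown alone.

In a functional assay on MCF7 cells (Homo sapiens) for antiproliferative activity, read by MTT assay, with a stated time of 48 h (on this read-out higher numbers stand for weaker inhibition and lower numbers for stronger inhibition), compound 1 (`O=C(/C=C/c1ccc(C(F)(F)F)cc1)Nc1nnc(-c2ccc(Br)cc2)s1`) gives 1.58 ug/mL and compound 2 (`COc1ccc(-c2nnc(NC(=O)/C=C/c3ccccc3)s2)cc1`) gives 0.78 ug/mL as the lower of the two numbers, a gap beyond the scatter. Compound 3 (`O=C(/C=C/c1ccccc1)Nc1nnc(-c2ccc(Br)cc2)s1`) differs from compound 2 by bromo in place of methoxy on an aromatic carbon as bromo in place of methoxy on an aromatic carbon, 4-methoxyphenyl to 4-bromophenyl. Within the data shown here, no measured step isolates this change. Compound 1 also carries 4-bromophenyl and gives 1.58 ug/mL so a moderate rise toward weaker inhibition is expected. The expected move is a 1.8-fold higher number from compound 2 to compound 3 (0.25 log units; within the scatter) in size. Compound 3 is estimated at 1.4 ug/mL within an expected range from 0.5 ug/mL to 4 ug/mL on this read-out.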

Compound 3, half-maximal inhibitory concentration: 1.5 ug/mL
Estimate against measurement, compound 3: 1.1-fold (0.03 log units) below, and the stated range covers the measured number.
By their numbers in this assay, from the lowest: compounds 2, 3 and 1 (each within the scatter of the next, the first and the last beyond it).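

In this assay bromo in place of methoxy on an aromatic carbon comes to a 1.9-fold higher number from compound 2 to compound 3 (0.28 log units; within the scatter) and hydrogen in place of trifluoromethyl on an aromatic carbon comes to a 1.1-fold lower number from compound 1 to compound 3 (0.02 log units; within the scatter) so neither single change separates its pair. Each place therefore tolerates its change on this read-out, with no effect resolved from the scatter so far. No supporting data bear on either step.

Open, from the compounds shown here alone, is whether an amine or a carboxylic acid in that para place would shift the number beyond the scatter. Going by these compounds, a longer alkoxy chain there is equally open.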